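The source may hold more compounds than are shown below. What is called first, only, known or untested is meant among the compounds shown, and "the series" means these compounds.

Compound 1 `COc1ccc(-c2nc(/N=C(\N)[N+]3(C)CCCCC3)sc2-c2ccc(OC)cc2)cc1` gives 21 uM
Compound 2 `COc1ccc(-c2nc(CNC(=O)c3cccnc3)sc2-c2ccc(OC)cc2)cc1` gives 8.2 uM
Compound 3 `COc1ccc(-c2nc(CNC(=O)CSC)sc2-c2ccc(OC)cc2)cc1` gives 6 uM

In a functional assay (aorta) with Rattus norvegicus as the target (a higher number here means that more compound is needed for the effect, a lower number that less compound is needed), compound 3 shares the low end of these numbers with compound 2, within the scatter. The next compound is compound 4 `COc1ccc(-c2nc(C(=O)N(C)C)sc2-c2ccc(OC)cc2)cc1`, which differs from compound 3 as follows: dimethylcarbamoyl in place of ((((methylsulfanyl)methyl)carbonyl)amino)methyl on an aromatic carbon. Changing the group on this aromatic carbon has given a 2.6-fold lower number from compound 1 to compound 2 (0.41 log units; beyond the scatter) and a 3.5-fold lower number from compound 1 to compound 3 (0.54 log units; beyond the scatter), both modest, while a change on the carbonyl carbon gave only a 1.4-fold lower number from compound 2 to compound 3 (0.14 log units; within the scatter). Within the data shown here, no measured compound carries dimethylcarbamoyl, so the direction stays open, and at most a modest step is expected. The working expectation in this assay is a 1.3-fold higher number from compound 3 to compound 4 (0.12 log units; within the scatter), no clear shift. Compound 4 is estimated at 8 uM, with an expected range of 3 uM to 22 uM overall.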

Compound 4, concentration for half-maximal effect: 3 uM
Compound 4: middle estimate off by 2.7-fold (0.43 log units), on the high side; measured number inside the range.
By their numbers in this assay, from the lowest: compounds 4, 3 and 2 (each within the scatter of the next, the first and the last beyond it); then compound 1.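

On this aromatic carbon, dimethylcarbamoyl, with 0 hydrogen-bond donors, does as well as the longer ((((methylsulfanyl)methyl)carbonyl)amino)methyl chain, at a 2.0-fold lower number from compound 3 to compound 4 (0.30 log units; within the scatter), so that chain and its hydrogen-bond donor are not needed for a number in this range. Among these compounds, the same group also gives a 2.7-fold lower number from compound 2 to compound 4 (0.44 log units; beyond the scatter), and the widest step at this position so far is a 7.0-fold lower number from compound 1 to compound 4 (0.85 log units; beyond the scatter). No measurement at hand explains these steps. The compounds shown leave open whether a primary amide, a carboxylic acid or a diethylamide on this carbon would hold or lower the number. They also leave open what replacing either 4-methoxyphenyl group would do.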